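The source may report more compounds than this note shows. Statements on the series, on what has been measured and on what is new or still open speak of the compounds shown alone.

Compound 1 `Cc1onc(NS(=O)(=O)c2ccc(N)cc2)c1I` gives 11000 nM in an assay on A7R5 cells for displacement of a labelled ligand from Endothelin-1 receptor (Rattus norvegicus); on this read-out lower numbers stand for stronger inhibition and higher numbers for weaker inhibition. Compound 3 `Cc1onc(NS(=O)(=O)c2ccc(C(C)(C)C)cc2)c1I` returns only a limit of this assay, > 100000 nM. The change from compound 1 to compound 3 amounts to an at least 9.0-fold higher number from compound 1 to compound 3 (0.95 log units; beyond the scatter). Compound 2 `COc1cccc(Sc2c(NS(=O)(=O)c3ccc(C(C)(C)C)cc3)noc2CCC/C=N/O)c1` gives 1500 nM, the lower of the two numbers seen, and the number of compound 1 stands higher. Compound 4 `COc1cccc(Sc2c(NS(=O)(=O)c3ccc(C(C)(C)C)cc3)noc2CCCC(C)=O)c1` differs from compound 2 by a group of 3 heavy atoms (2 carbon, 1 oxygen; no ring) in place of a group of 3 heavy atoms (1 carbon, 1 nitrogen, 1 oxygen; no ring), on a saturated chain carbon, three bonds along the chain from an aromatic carbon. Among the compounds with values here, no measured step touches this part of the chain: the one step known swaps a group on an aromatic carbon and leaves the chain untouched, so the data give no guide to direction or size here. The expected step is a 1.3-fold higher number from compound 2 to compound 4 (0.12 log units; within the scatter), small and within the usual scatter. Compound 4 is therefore expected to give 2000 nM, with a likely range from 700 nM to 6000 nM.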

Compound 4, half-maximal inhibitory concentration: 1300 nM
The estimate for compound 4 lay 1.5-fold (0.19 log units) above the measured number; measured number inside the range.
By their numbers in this assay, from the lowest: compounds 4 and 2 (each within the scatter of the next); then compound 1. At a limit, above all of these: compound 3.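

Putting acetyl on a saturated chain carbon, three bonds along the chain from an aromatic carbon, gives a 1.2-fold lower number from compound 2 to compound 4 (0.06 log units; within the scatter) so this assay does not tell the two compounds apart. The group that leaves holds 1 hydrogen-bond donor and acetyl holds 0, so that donor is not required for a number of this size. No measurement shown accounts for this result. Still open, as far as these compounds go, is whether a carboxylic acid, an amine or a longer chain at this place would shift the number.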